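Two Measured Compounds and an Expected Shift

A few compounds are considered here, and "the series" means these few. Any claim that something is new, unique, unknown or untested is made for them only; others in the source may bear on it.

Compound 1 `COc1ccc(/C=C/C(=O)c2ccc(OC)c3c2OC(C)(C)C=C3)cc1OCCO`: 9600 nM
Compound 2 `COc1ccc(/C=C/C(=O)c2ccc(OC)c3c2OC(C)(C)C=C3)cc1OCCCN(C)C`: 4100 nM

In a functional assay on A-375 cells (Homo sapiens) for cytotoxicity, read by MTT assay (a higher number here means a weaker inhibitor, a lower number a stronger inhibitor), compound 2 has the lower of the two numbers at 4100 nM, while compound 1 gives 9600 nM. The next compound to be tested is compound 3 `CCC(=O)Oc1cc(/C=C/C(=O)c2ccc(OC)c3c2OC(C)(C)C=C3)ccc1OC`, which carries propanoyl in place of 3-(dimethylamino)propyl on an oxygen on an aromatic ring. Among the measured compounds shown here, only one measured step bears on this change: a 2.3-fold lower number from compound 1 to compound 2 (0.37 log units; beyond the scatter). That modest step also altered the chain on this oxygen, and it introduced the dimethylamino end that compound 3 lacks. For the measured compounds named here, with so little data, this single step is the only guide, and it suggests that removing that end may reverse the gain. A modest move to a higher number is therefore expected, estimated as a 2.2-fold higher number from compound 2 to compound 3 (0.34 log units; beyond the scatter). For compound 3, the expected value is 9000 nM, with an estimated range of 3000 nM to 25000 nM.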

Compound 3, half-maximal inhibitory concentration: 240 nM
Compound 3: the middle estimate sits 38-fold (1.57 log units) above what was measured; the whole stated range lies above it.
By their numbers in this assay, from the lowest: compound 3; then compound 2; then compound 1.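

In this assay the substituent on this oxygen on an aromatic ring matters far more than the earlier pair could show: propanoyl in place of 3-(dimethylamino)propyl gives a 17-fold lower number from compound 2 to compound 3 (1.23 log units; beyond the scatter), and propanoyl in place of 2-hydroxyethyl gives a 40-fold lower number from compound 1 to compound 3 (1.60 log units; beyond the scatter). Both steps are large, whereas the step between the two earlier chains, a 2.3-fold lower number from compound 1 to compound 2 (0.37 log units; beyond the scatter), is modest, so among these three compounds the move to propanoyl counts for much more than the change at the end of the chain. Nothing available accounts for this gain.

The compounds shown leave open whether the carbonyl of propanoyl or the length of its chain carries the effect. A plain propyl on the same oxygen would address the first question, and acetyl or butanoyl the second.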